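Methoxymethyl for fluoromethyl on a shared core

The compounds below may be only part of what the source reports. "The series", "measured", "known", "first", "only" and "open" are said of these compounds alone.

- Compound 1 `COC[C@H](C)[C@H](C)C(c1ccc(O)c(OC)c1)c1ccc(O)c(OC)c1`: 72000 nM
- Compound 2 `COc1cc(C(c2ccc(O)c(OC)c2)[C@@H](C)[C@@H](C)CF)ccc1O`: 42000 nM

Among the compounds with values here, in a functional assay on HeLa cells (Homo sapiens) for cytotoxicity, read by WST assay, with a stated time of 48 h (on this read-out lower numbers stand for stronger inhibition and higher numbers for weaker inhibition), compound 2 stands within the scatter of compound 1, the only other measured compound. Compound 3 `COC[C@H](C)[C@@H](C)C(c1ccc(O)c(OC)c1)c1ccc(O)c(OC)c1` is reached from compound 2 by one change: 2-(methoxymethyl)-1-methylpropyl in place of 2-(fluoromethyl)-1-methylpropyl on a saturated chain carbon bound to two aromatic carbons. Within the data shown here, the only measured step bearing on this is the opposite exchange of methoxy and fluoro, a 1.7-fold lower number from compound 1 to compound 2 (0.23 log units; within the scatter). Among the measured compounds shown here, compound 3 also differs from compound 1 at one defined stereocentre, and no measured step covers that difference. No change beyond the scatter is therefore expected, and the estimated step is a 1.4-fold higher number from compound 2 to compound 3 (0.15 log units; within the scatter). For compound 3 the expected value is 60000 nM, with an estimated range of 25000 nM to 130000 nM.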

Compound 3, half-maximal inhibitory concentration: 77000 nM
Compound 3: the middle estimate sits 1.3-fold (0.11 log units) below what was measured; the range from low to high includes it.
By their numbers in this assay, from the lowest: compounds 2, 1 and 3 (each within the scatter of the next).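

In this assay, the drawn configuration at one stereocentre can now be read on its own, and the step is a 1.1-fold higher number from compound 1 to compound 3 (0.03 log units; within the scatter). That reading rests on a clean pair: the fact that compounds 1 and 3 differ only in the configuration as drawn. The exchange of 2-(fluoromethyl)-1-methylpropyl for 2-(methoxymethyl)-1-methylpropyl, read in this direction, also gives no separation, with a 1.8-fold higher number from compound 2 to compound 3 (0.26 log units; within the scatter).

The compounds shown leave open whether an amine, a carboxylic acid or a longer chain at this place would move the number beyond the scatter. On these data alone, the effect of the second stereocentre also remains open.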